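Methylamino for Methyl: Expected Cytotoxicity of a Urea Analogue

The source may report more compounds than this note shows. Statements on the series, on what has been measured and on what is new or still open speak of the compounds shown alone.

Measured so far in a functional assay on HepG2 cells (Homo sapiens) for cytotoxicity, read by MTT assay, with a stated time of 72 h; a higher number here means a weaker inhibitor, a lower number a stronger inhibitor:
compound 1 `O=C(Nc1ccc(-n2ncc3c(Cl)cccc32)cc1)Nc1ccc(Cl)c(C(F)(F)F)c1`: 1900 nM
compound 2 `Cc1cccc2c1cnn2-c1ccc(NC(=O)Nc2ccc(Cl)c(C(F)(F)F)c2)cc1`: 4000 nM

Of these two numbers, compound 2 gives the higher one, the step being a 2.1-fold higher number from compound 1 to compound 2 (0.32 log units; beyond the scatter). Compound 3 `CNc1cccc2c1cnn2-c1ccc(NC(=O)Nc2ccc(Cl)c(C(F)(F)F)c2)cc1` differs from compound 2 in a single place: methylamino in place of methyl on an aromatic carbon. For the measured compounds named here, no measured step covers this exact change. Going by the values given here, the only step known, a 2.1-fold higher number from compound 1 to compound 2 (0.32 log units; beyond the scatter), exchanged groups at this same place and was modest, so a similarly modest shift, in no firm direction, is expected; for compound 3 the expected step is no change at the digits printed from compound 2 to compound 3 (within the scatter). Compound 3 is therefore estimated at 4000 nM, with a range from 1500 nM to 11000 nM.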

Compound 3, half-maximal inhibitory concentration: 3000 nM
For compound 3 the middle estimate is 1.3-fold (0.12 log units) above the measured one; the measured number falls inside the stated range.
By their numbers in this assay, from the lowest: compounds 1, 3 and 2 (each within the scatter of the next, the first and the last beyond it).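

In this assay, methylamino at this aromatic carbon adds a hydrogen-bond donor and a hydrogen-bond acceptor that methyl does not have, yet the result is a 1.3-fold lower number from compound 2 to compound 3 (0.12 log units; within the scatter). Set against chloro at the same carbon, the result is a 1.6-fold higher number from compound 1 to compound 3 (0.20 log units; within the scatter). So, among these three compounds, a group with a donor can sit at this carbon with neither step going beyond the scatter. No measurement here offers an explanation for this result. On these data alone, whether a larger amine such as dimethylamino, or a carboxylic acid, would shift the number at this carbon remains open.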